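The source may hold more compounds than are shown below. What is called first, only, known or untested is meant among the compounds shown, and "the series" means these compounds.

Three compounds have a number in an in vitro functional assay on HEK ts201 cells for antagonist activity at Neuronal acetylcholine receptor; alpha4/beta2 (Homo sapiens), read by fluorescence and calcium flux; a lower number here means a stronger inhibitor, a higher number a weaker inhibitor. Compound 1 `O=C(OCC1=CCCN(CCCc2ccccc2)C1)c1ccccc1N1C(=O)CC(Cc2ccccc2)C1=O` gives 5130 nM in this assay. Compound 2 `COc1ccc(OCCCCCN2CCCC(COC(=O)c3coc4ccccc4c3=O)C2)cc1` gives 10000 nM in this assay. Compound 3 `CC1CC(=O)N(c2ccccc2C(=O)OCC2CCCN(CCCCOc3ccccc3)C2)C1=O` gives 1700 nM in this assay, the lowest of the three; compound 1 sits higher and compound 2 higher still, both beyond the scatter of repeated measurements. No pair among these three differs in a single place, so no single-point step is known here.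

Compound 4 `CC1CC(=O)N(c2ccccc2C(=O)OCC2CCCN(CCCCCOc3ccccc3)C2)C1=O` is the next compound, not yet measured. Against compound 3 the difference is phenoxymethyl in place of phenoxy on a saturated chain carbon, four bonds along the chain from an amine nitrogen in a ring. Because compound 3 gives 1700 nM and the change adds one saturated carbon to a chain otherwise kept, the step is expected to be small, in either direction, and most likely within the scatter. The number for compound 4 is estimated at 1700 nM, within a range from 600 nM to 5000 nM. That estimate means a step of no change at the digits printed from compound 3 to compound 4 (within the scatter) in this assay, which is expected to stay inside the usual scatter.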

Compound 4, half-maximal inhibitory concentration: 17000 nM
For compound 4 the middle estimate is 10-fold (1.00 log units) below the measured one, outside the stated range (above it).
By their numbers in this assay, from the lowest: compound 3; then compounds 1, 2 and 4 (each within the scatter of the next, the first and the last beyond it).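

In this assay, among the compounds shown here, phenoxymethyl in place of phenoxy on a saturated chain carbon, four bonds along the chain from an amine nitrogen in a ring, brings a 10-fold higher number from compound 3 to compound 4 (1.00 log units; beyond the scatter) and gives the first comparison here of two compounds differing in one place. It shows that this position is not indifferent to chain length: one added saturated carbon is enough to carry the number well beyond the scatter, although the counts of hydrogen-bond donors and acceptors in the two groups are the same. Nothing at hand offers an explanation for this step.

Going by these compounds, with a single step known, it stays open whether a shorter chain would give a lower number than compound 3 or a higher one. On these data alone, it is also open whether an amide in place of the ether oxygen in this chain would change the number at the length of compound 3.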